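The source may report more compounds than this note shows. Statements on the series, on what has been measured and on what is new or still open speak of the compounds shown alone.

Measured so far in an assay on cells for inhibition of Palmitoleoyl-protein carboxylesterase NOTUM variant C330S (Homo sapiens), read by fluorescence, with a stated time of 40 min; on this read-out higher numbers stand for weaker inhibition and lower numbers for stronger inhibition:
compound 1 `Cc1cc(C(=O)O)c(C)n1-c1cccc(C(C)C)c1`, 360 nM
compound 2 `COc1cccc(-n2c(C)cc(C(=O)O)c2C)c1`, 1500 nM

Compound 2 stands at the highest of these two numbers; its nearest neighbour is compound 1, the step being a 4.2-fold higher number from compound 1 to compound 2 (0.62 log units; beyond the scatter). Compound 3 `Cc1cc(C(=O)O)c(C)n1-c1cccc(C#N)c1` differs from compound 2 by cyano in place of methoxy on an aromatic carbon. Among the compounds with values here, the single measured step, a 4.2-fold higher number from compound 1 to compound 2 (0.62 log units; beyond the scatter), changes the same aromatic carbon but concerns isopropyl and methoxy, not cyano, so it fixes neither direction nor size for this exchange. In this assay a step not beyond the usual scatter is expected, as a 1.3-fold lower number from compound 2 to compound 3 (0.10 log units; within the scatter). Compound 3 is estimated at 1200 nM, within 400 nM to 3600 nM.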

Compound 3, half-maximal inhibitory concentration: 3100 nM
Compound 3: the middle estimate sits 2.6-fold (0.41 log units) below what was measured; the measured number falls inside the stated range.
By their numbers in this assay, from the lowest: compound 1; then compound 2; then compound 3.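

In this assay cyano on this aromatic carbon brings a 2.1-fold higher number from compound 2 to compound 3 (0.32 log units; beyond the scatter) even though both groups hold the same count of heavy atoms, so this exchange is not neutral at this position. Against isopropyl the change is larger, with an 8.6-fold higher number from compound 1 to compound 3 (0.94 log units; beyond the scatter) and the numbers rising from isopropyl through methoxy to cyano across these three compounds. No evidence bears on the reason for this order.
Where a chlorine atom, an amine or a longer chain such as butyl would fall in this order stays open. On these data alone, whether the order holds with the carboxylic acid or the two methyl groups of the core changed also stays open.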